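The source may hold more compounds than are shown below. What is called first, only, known or untested is meant among the compounds shown, and "the series" means these compounds.

The study begins with two compounds examined in an assay on membranes from Cerebral cortex for binding affinity to Adrenergic receptor alpha-1 (Rattus norvegicus); on this read-out higher numbers stand for weaker inhibition and lower numbers for stronger inhibition. Compound 1 `O=C1C2CCCN2C(=O)CN1CN1CCN(c2cccc3c2CC=COO3)CC1` does not yield a number: in this assay compound 1 gives > 1000 nM, which is a limit of the assay. Compound 2 `C[C@@H]1CN(c2cccc3ccccc23)CCN1CN1CC(=O)N2CCC[C@H]2C1=O` behaves the same way, and in this assay compound 2 gives > 1000 nM, again a limit rather than a measured figure. Within the data shown here, compound 2 thus stands at the edge of what the assay reports, a position it shares with the only other value shown, since (the limit of > 1000 nM in this assay, at which 2 of the 2 values shown sit). The account now turns to compound 3 `C[C@H]1CN(c2cccc3ccccc23)CCN1CN1CC(=O)N2CCC[C@@H]2C1=O`, whose relation to compound 2 is this: the two compounds have the same atoms and bonds and differ only in configuration as drawn: 2 of 2 stereo elements differ (all stereocentres are inverted: mirror images); a stereocentre at a saturated ring carbon is drawn R in compound 2 and S in compound 3; a stereocentre at a saturated ring carbon is drawn S in compound 2 and R in compound 3. Among the measured compounds shown here, no measured step between compounds is available to gauge the effect of such a change. The expected step that the limit leaves unreadable from compound 2 to compound 3 is therefore small, with no direction beyond the usual scatter. Compound 3 is estimated at 1500 nM in this assay, within a range from 500 nM to 6000 nM, and is expected most likely to come back as a limit once more.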

Compound 3, inhibition constant: > 1000 nM
Compound 3 gave a limit, no number; the forecaster's own chance of this, stated with the estimate: 70%; the middle value lies beyond the limit too.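

No step can be read between compound 2 and compound 3, as the result for each is only a limit in this assay: the limit of > 1000 nM in this assay, at which 3 of the 3 values shown sit.

The compounds shown leave open what affinity any of them has, and whether inverting both stereocentres changes it at all.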